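Piperazine nitrogen substituent series: next step to benzyl

The source may hold more compounds than are shown below. What is called first, only, known or untested is meant among the compounds shown, and "the series" means these compounds.

Measured so far:
- compound 1 `CN1CCN(CC(=O)Nc2ccc(-c3nc(-c4ccccc4)c(-c4ccccc4)n3C)cc2)CC1` — 46.2%
- compound 2 `Cn1c(-c2ccc(NC(=O)CN3CCN(c4ccccc4)CC3)cc2)nc(-c2ccccc2)c1-c1ccccc1` — 63.6%

Both numbers come from a functional assay on MCF7 cells (Homo sapiens) for cytotoxicity, read by MTT assay, with a stated time of 24 h, tested at 32 ug/mL; on this read-out higher numbers stand for a stronger effect at the one concentration tested and lower numbers for a weaker effect. Within the data shown here, compound 2 stands highest of the two measured numbers; the only neighbour is compound 1, and the step of a number 17.4 percentage points higher from compound 1 to compound 2 (beyond the scatter) lies beyond the scatter and is modest in size.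

Compound 3 `Cc1ccc(CN2CCN(CC(=O)Nc3ccc(-c4nc(-c5ccccc5)c(-c5ccccc5)n4C)cc3)CC2)cc1` is not yet measured in this assay. It differs from compound 2 by 4-methylbenzyl in place of phenyl on an amine nitrogen in a ring.

Among the measured compounds shown here, no measured step bears directly on this change: the single step known, from compound 1 to compound 2, replaces methyl with phenyl on the same ring nitrogen and says nothing about phenyl against 4-methylbenzyl. Both compound 2 and compound 3 carry an aromatic group on that nitrogen, so the expectation rests on compound 2 alone. The step of a number 3.6 percentage points lower from compound 2 to compound 3 (within the scatter) is expected to stay within the scatter, in no clear direction. Compound 3 is therefore estimated at 60% in this assay, with a range from 42% to 78% that allows for the absence of any directly comparable step.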

Compound 3, a percentage reported as activity, at one concentration (the size of the read-out at that concentration, not a potency): 31.5%
For compound 3 the middle estimate is 28.5 percentage points above the measured one, and the stated range ends above it.
By their numbers in this assay, from the lowest: compound 3; then compound 1; then compound 2.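

In this assay the ring nitrogen proves more sensitive than the earlier pair suggested, with the change from phenyl to 4-methylbenzyl giving a number 32.1 percentage points lower from compound 2 to compound 3 (beyond the scatter), a large step even though both groups carry one six-membered aromatic ring of carbon only and neither adds a hydrogen-bond donor, a hydrogen-bond acceptor or a net charge. An aromatic ring on this nitrogen therefore does not by itself secure the higher read-out, since the change from methyl to 4-methylbenzyl gives a number 14.7 percentage points lower from compound 1 to compound 3 (beyond the scatter), in the opposite direction to a number 17.4 percentage points higher from compound 1 to compound 2 (beyond the scatter). Among these three compounds the read-out does not rise with the size of the nitrogen substituent, as the largest group, in compound 3, stands lowest, and compound 1, with the smallest, stands in the middle.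

A plain benzyl and a 4-methylphenyl on the same nitrogen would show whether the loss goes with the saturated carbon of the benzyl group or with the methyl on its ring, a question the three compounds leave open. Nothing measured here on any property of these compounds accounts for the fall.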